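This account rests on a few compounds, and the source may have more. Where it says the series, first, only, none or still open, it means among the compounds named here.

Measured so far in a functional assay on A498 cells (Homo sapiens) for inhibition, read by sulforhodamine B assay, with a stated time of 48 h; a lower number here means that less compound is tolerated, a higher number that more compound is tolerated:

- compound 1 `O=C(Nc1cccc(-n2cc(-c3ccncc3)c(-c3ccc(Cl)c(O)c3)n2)c1)Nc1cccc(C(F)(F)F)c1` gives > 32500 nM; this is a limit of the assay, not a number.
- compound 2 `COc1cc(-c2nn(-c3cccc(NC(=O)Nc4cc(C(F)(F)F)cc(C(F)(F)F)c4)c3)cc2-c2ccncc2)ccc1Cl` gives 7140 nM.
- compound 3 `COc1cc(-c2nn(-c3cccc(NC(=O)Nc4cccc(C(F)(F)F)c4)c3)cc2-c2ccncc2)ccc1Cl` gives > 50000 nM; this too is a limit of the assay, not a number.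

Going by the values given here, compound 2 thus holds the only number in this assay among the three; the other two values are limits. Compound 4 `O=C(Nc1cccc(-n2cc(-c3ccncc3)c(-c3ccc(Cl)c(O)c3)n2)c1)Nc1cc(C(F)(F)F)cc(C(F)(F)F)c1` is to be measured next. It differs from compound 2 by hydrogen in place of methyl on an oxygen on an aromatic ring, the same exchange cut one bond further out reading methoxy to hydroxy, on a 4-chloro-3-methoxyphenyl becoming 4-chloro-3-hydroxyphenyl.

Among the compounds with values here, the one measured step that carries this exchange, in the reverse direction, is a step that the two limits leave unreadable from compound 1 to compound 3; it cannot be read because the limit of > 32500 nM in this assay, at which 1 of the 3 values shown sits, and the limit of > 50000 nM in this assay, at which 1 of the 3 values shown sits, bound both of its ends. The other step, an at least 7.0-fold higher number from compound 2 to compound 3 (0.84 log units; beyond the scatter), concerns a trifluoromethyl and does not bear on the oxygen. Nothing measured therefore sizes the methyl-to-hydrogen exchange, and for compound 4 a step of a 1.3-fold higher number from compound 2 to compound 4 (0.10 log units; within the scatter) is expected, within the scatter. Compound 4 is accordingly estimated at 9000 nM, between 3000 nM and 30000 nM.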

Compound 4, concentration lethal to 50% of the cells: 16000 nM
Compound 4: the middle estimate sits 1.8-fold (0.25 log units) below what was measured; the range from low to high includes it.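

In this assay, the exchange of methyl for hydrogen on an oxygen on an aromatic ring, methoxy to hydroxy, now has a readable size: a 2.2-fold higher number from compound 2 to compound 4 (0.35 log units; beyond the scatter). The same exchange between compound 1 and compound 3 cannot be read, as both ends of that step are limits. Trifluoromethyl in place of hydrogen on an aromatic carbon now also has a reading on the hydroxy side, an at least 2.0-fold lower number from compound 1 to compound 4 (0.30 log units; that floor lies within the scatter), which gives two readings of that change: the same change on two cores in this assay, an at least 7.0-fold higher number (0.84 log units; beyond the scatter) from compound 2 to compound 3 and an at least 2.0-fold higher number (0.30 log units; that floor lies within the scatter) from compound 4 to compound 1; the limit leaves it open whether they differ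

On these data alone, what an amine or an ethoxy in place of the methoxy of compound 2 would give stays open. Also open, as far as these compounds go, is whether methoxy to hydroxy has the same size on the core of compound 3, where only limits stand.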